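A few compounds are considered here, and "the series" means these few. Any claim that something is new, unique, unknown or untested is made for them only; others in the source may bear on it.

Compound 3 `CC(C)Nc1nc(Nc2ccc(N3CCN(C)CC3)cc2)ncc1/N=C/c1ccc(C(F)(F)F)cc1` stands at the edge of what a functional assay on MCF7 cells (Homo sapiens) for antiproliferative activity, read by MTT assay (on this read-out higher numbers stand for weaker inhibition and lower numbers for stronger inhibition), can report: compound 3 gives > 100000 nM, which is a limit of the assay and not a number. Compound 1 `CN1CCN(c2ccc(Nc3ncc(/N=C/c4ccc(C(F)(F)F)cc4)c(NC4CCCC4)n3)cc2)CC1` sits at a limit too; in this assay compound 1 gives > 100000 nM. Among the measured compounds shown here, compound 2 `CC(C)Nc1nc(Nc2ccc(N3CCN(C)CC3)cc2)ncc1/N=C/c1cccs1` is the only one with a number; in this assay compound 2 gives 91100 nM. The step of an at least 1.0-fold higher number from compound 2 to compound 3 (0.04 log units; that floor lies within the scatter) alters only the group on the carbon with a double bond to nitrogen, and the step that the two limits leave unreadable from compound 1 to compound 3 alters only the group on the nitrogen on the aromatic ring. Two of the three values share one limit (the limit of > 100000 nM in this assay, at which 2 of the 3 values shown sit). Compound 4 `CC(C)Nc1nc(Nc2ccc(S(N)(=O)=O)cc2)ncc1/N=C/c1ccc(C(F)(F)F)cc1` differs from compound 3 in a single place: sulfamoyl in place of 4-methylpiperazin-1-yl on an aromatic carbon. Neither measured step touches that position, so none bears on it. Because compound 3 sits at > 100000 nM, the expected step of an at least 1.6-fold lower number from compound 3 to compound 4 (0.22 log units; that floor lies within the scatter) is read from a limit, and no step beyond the scatter is expected. Compound 4 is estimated at 60000 nM, with a range from 10000 nM to 100000 nM.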

Compound 4, half-maximal inhibitory concentration: > 100000 nM
Compound 4: a limit, no number; the forecaster's own chance of this, stated with the estimate: 50%; middle value at least 1.6-fold (0.22 log units) away from the limit.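

In this assay compound 4 gives > 100000 nM, which is a limit and not a number. Compound 3 sits at a limit too, and no step can be read between compound 3 and compound 4. The compounds shown leave open whether sulfamoyl in place of 4-methylpiperazin-1-yl changes the value at all.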